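The source may report more compounds than this note shows. Statements on the series, on what has been measured and on what is new or still open speak of the compounds shown alone.

Compound 1 `N#Cc1c(N2CCC(c3ccccc3F)CC2)ccn(CC2CC2)c1=O`: 282%
Compound 2 `N#Cc1c(N2CCC(c3ccc(F)cc3F)CC2)ccn(CC2CC2)c1=O`: 272%

Both were tested in a functional assay on CHO cells for positive allosteric modulation of metabotropic glutamate receptor 2 (Homo sapiens), with a stated time of 30 min; on this read-out lower numbers stand for smaller maximal responses and higher numbers for larger maximal responses. For the measured compounds named here, compound 2 is one of only two compounds measured, and the step of a number 10 percentage points lower from compound 1 to compound 2 (within the scatter) lies within the scatter, so compound 2 and compound 1 cannot be told apart on this read-out. Compound 3 `N#Cc1c(N2CCC(c3c(F)cccc3F)CC2)ccn(CC2CC2)c1=O` differs from compound 2 by 2,6-difluorophenyl in place of 2,4-difluorophenyl on a saturated ring carbon. Going by the values given here, the one measured step, fluoro in place of hydrogen on an aromatic carbon, changed nothing beyond the scatter, and the move to compound 3 keeps the same atoms joined differently. No shift beyond the scatter is therefore expected. Compound 3 is estimated to give 272%, between 235% and 310%, a step of no change at the digits printed from compound 2 to compound 3 (within the scatter).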

Compound 3, largest response reached (Emax), in percent of the reference or control that the assay uses: 291%
Compound 3: middle estimate off by 19 percentage points, on the low side; low and high end bracket the measured number.
By their numbers in this assay, from the lowest: compounds 2, 1 and 3 (each within the scatter of the next, the first and the last beyond it).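

Swapping 2,4-difluorophenyl for 2,6-difluorophenyl on the saturated ring carbon, with the same atoms joined differently, gives a number 19 percentage points higher from compound 2 to compound 3 (beyond the scatter) in this assay as the first step here beyond the scatter. The other step to the new compound, a number 9 percentage points higher from compound 1 to compound 3 (within the scatter), cannot be told from noise, so among these three compounds only the two difluorophenyl isomers differ on this read-out. Nothing available explains why this rearrangement shifts the response.

From the compounds shown here alone, whether a chlorine atom or a methoxy group on the phenyl ring would give a similar maximal response remains open, as does the effect of an amine there.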